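This account rests on a few compounds, and the source may have more. Where it says the series, first, only, none or still open, it means among the compounds named here.

Compound 1 `CN(C)c1ccc(N2C(=O)NC3(CSC4=C3C(=O)c3ncccc3C4=O)C2=O)cc1`: 10 nM
Compound 2 `O=C1NN(c2ccccc2)C(=O)C2(CSC3=C2C(=O)c2ncccc2C3=O)N1`: 210 nM

Going by the values given here, in a functional assay on HeLa cells (Homo sapiens) for antiproliferative activity, read by MTT assay, with a stated time of 96 h (a higher number here means a weaker inhibitor, a lower number a stronger inhibitor), compound 1 gives 10 nM, the lower of the two numbers measured so far; compound 2 gives 210 nM, a higher number by a margin beyond the scatter. Compound 3 `O=C1C2=C(C(=O)c3ncccc31)C1(CS2)NC(=O)N(c2ccncc2)C1=O` has not been measured. It differs from compound 1 in one place: pyridin-4-yl in place of 4-(dimethylamino)phenyl on an amide-type nitrogen in a ring. Among the compounds with values here, no measured pair shows this particular change, so its effect is unknown. In this assay the change is expected to raise the number moderately, estimated as a 4.0-fold higher number from compound 1 to compound 3 (0.60 log units; beyond the scatter). Compound 3 is therefore expected to give 40 nM, within a range of 8 nM to 200 nM.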

Compound 3, half-maximal inhibitory concentration: 10 nM
For compound 3 the middle estimate is 4.0-fold (0.60 log units) above the measured one, and the stated range covers the measured number.
By their numbers in this assay, from the lowest: compounds 1 and 3 (each within the scatter of the next); then compound 2.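

In this assay, going by these compounds alone, pyridin-4-yl in place of 4-(dimethylamino)phenyl on the amide-type nitrogen in the ring gives no change at the digits printed from compound 1 to compound 3 (within the scatter), the first reading of any change at this position. The 4-(dimethylamino)phenyl group is therefore not required for a number this low on the core of compound 1. Nothing at hand accounts for this result.

From the compounds shown here alone, whether an unsubstituted phenyl, pyridin-3-yl, or a phenyl bearing a carboxylic acid or a longer chain would give a similar number remains open. Compound 2 differs from compound 1 in more than one place, so it cannot settle this.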